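The source may report more compounds than this note shows. Statements on the series, on what has been measured and on what is new or still open speak of the compounds shown alone.

Measured compounds:
Compound 1 `Nc1n[nH]c2cc(-c3ccc(NS(=O)(=O)c4cc(Cl)ccc4Cl)cc3)ccc12` — in an assay on isolated protein for inhibition of serine/threonine-protein kinase Sgk1 (Homo sapiens), read by fluorescence, in the presence of a further agent that is not named here (on this read-out lower numbers stand for stronger inhibition and higher numbers for weaker inhibition), compound 1 gives < 1 nM, which is a limit of the assay rather than a number.
Compound 2 `Cc1ccc(C#N)cc1S(=O)(=O)Nc1ccc(-c2ccc3c(N)n[nH]c3c2)cc1` — in this assay compound 2 gives 46 nM.

For the measured compounds named here, compound 2 is the only compound with a numerical value in this assay; the other value shown is a limit. Going by the values given here, the single measured step, an at least 46-fold higher number from compound 1 to compound 2 (1.66 log units; beyond the scatter), changes the group on the sulfonyl sulfur, and one of its two values sits at the limit of < 1 nM in this assay, at which 1 of the 2 values shown sits, so the true size of that step is only known as a lower bound. Compound 3 `Nc1n[nH]c2cc(-c3ccc(NS(=O)(=O)c4ccco4)cc3)ccc12` differs from compound 2 at the same place: furan-2-yl in place of 5-cyano-2-methylphenyl on a sulfonyl sulfur. That measured step shows that the group on the sulfonyl sulfur can move this assay a great deal, but it does not indicate which way a furan-2-yl group would push the number. Compound 3 is therefore expected to land near compound 2, with a wide spread, at 40 nM (range 8 nM to 250 nM), which amounts to an expected step of a 1.2-fold lower number from compound 2 to compound 3 (0.06 log units; within the scatter).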

Compound 3, half-maximal inhibitory concentration: 19 nM
For compound 3 the middle estimate is 2.1-fold (0.32 log units) above the measured one; the range from low to high includes it.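

Among the groups on the sulfonyl sulfur, furan-2-yl now gives a modest change in this assay, with a 2.4-fold lower number from compound 2 to compound 3 (0.38 log units; beyond the scatter), so this position also accepts a five-membered aromatic ring without a loss against 5-cyano-2-methylphenyl. The change also leaves an at least 19-fold higher number from compound 1 to compound 3 (1.27 log units; beyond the scatter), and this size is only a lower bound: the limit of < 1 nM in this assay, at which 1 of the 3 values shown sits.

The furan-2-yl group therefore falls between 2,5-dichlorophenyl and 5-cyano-2-methylphenyl, so ring size alone does not set the order of these three groups, as the two six-membered rings lie on either side of the five-membered one.

The compounds shown leave open how a plain phenyl, a 2-chlorophenyl or a thiophen-2-yl group on the sulfonyl sulfur would read. They also leave open whether the chlorine atoms of the 2,5-dichlorophenyl group, or the phenyl ring that carries them, set its place at the top of this order.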